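Aryl exchange at the core of compound 1

The source may report more compounds than this note shows. Statements on the series, on what has been measured and on what is new or still open speak of the compounds shown alone.

compound 1 `Clc1cccc(-c2cc(-c3ccc(Cl)o3)cc(-c3cccs3)n2)c1` — 15500 nM
compound 2 `Cc1ccc(-c2cc(-c3ccoc3)cc(-c3ccsc3)n2)cc1` — 44800 nM
compound 3 `Clc1cccc(-c2cc(-c3ccc(Cl)o3)cc(-c3ccsc3)n2)c1` — 13700 nM

In a functional assay on HCT-15 cells (Homo sapiens) for cytotoxicity, in the presence of a further agent that is not named here (a higher number here means a weaker inhibitor, a lower number a stronger inhibitor), compound 1 gives 15500 nM, the second highest of the three numbers. Compound 3 lies nearest to it, a 1.1-fold lower number from compound 1 to compound 3 (0.05 log units; within the scatter), while compound 2 stands furthest with a higher number. The step to compound 4 `Cc1ccc(-c2cc(-c3ccc(Cl)o3)cc(-c3cccs3)n2)cc1` is 4-methylphenyl in place of 3-chlorophenyl on an aromatic carbon. For the measured compounds named here, no measured step alters this position; the single measured step, a 1.1-fold lower number from compound 1 to compound 3 (0.05 log units; within the scatter), concerns a different ring. Compound 2 also carries a 4-methylphenyl group and shows a higher number than compound 1, but it differs in two further places, so its value bears only loosely on the step. For compound 4 a modestly higher number than compound 1 is therefore expected, a 1.6-fold higher number from compound 1 to compound 4 (0.21 log units; within the scatter), with a result within the scatter quite possible. The estimate for compound 4 is 25000 nM, ranging from 8000 nM to 80000 nM.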

Compound 4, half-maximal inhibitory concentration: 9890 nM
Estimate against measurement, compound 4: 2.5-fold (0.40 log units) above; the measured number falls inside the stated range.
By their numbers in this assay, from the lowest: compounds 4, 3 and 1 (each within the scatter of the next); then compound 2.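

With this assay, the exchange gives a 1.6-fold lower number from compound 1 to compound 4 (0.20 log units; within the scatter), so the aromatic carbon next to the ring nitrogen accepts 4-methylphenyl in place of 3-chlorophenyl without a step beyond the scatter. In this pair, the chlorine and its ring location can be exchanged with no resolved change in the number. No supporting measurement gives a reason for this result.

Still open, on these data alone, is how this position responds to an aryl group bearing an amine or a carboxylic acid, or to a longer chain. Whether the same exchange holds with other groups on the shared core also remains unsettled.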